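A Nitro for a Methoxy on a Weak Starting Point

The compounds below may be only part of what the source reports. "The series", "measured", "known", "first", "only" and "open" are said of these compounds alone.

The shared core of compound 1 `CCOC(=O)C1=Cc2ccccc2OC1(OCc1cc(-c2ccc(OC)cc2)no1)C(F)(F)F` carries a trifluoromethyl and an ethyl ester, and its side chain ends in a methoxy-bearing phenyl ring. In a functional assay on MCF7 cells (Homo sapiens) for inhibition, read by MTT assay, with a stated time of 24 h (a higher number here means a weaker inhibitor, a lower number a stronger inhibitor), compound 1 gives only a limit, > 150000 nM, and no number. Two companions on the same core were measured. Compound 2 `CCOC(=O)C1=Cc2ccccc2OC1(OCc1cn(CC(=O)Nc2ccccc2F)nn1)C(F)(F)F` gives 42100 nM in this assay. Compound 3 `CCCCCCCCn1cc(COC2(C(F)(F)F)Oc3ccccc3C=C2C(=O)OCC)nn1` gives only a limit in this assay, > 150000 nM. Among the compounds with values here, the one measured step, an at least 3.5-fold higher number from compound 2 to compound 3 (0.55 log units; beyond the scatter), runs away from the numbered value toward the limit, and it is underlined by the limit of > 150000 nM in this assay, at which 2 of the 3 values shown sit.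

Compound 4 `CCOC(=O)C1=Cc2ccccc2OC1(OCc1cc(-c2ccc([N+](=O)[O-])cc2)no1)C(F)(F)F` differs from compound 1 in a single place: nitro in place of methoxy on an aromatic carbon. Within the data shown here, no measured step touches this part of the molecule, since the only step recorded concerns the chain on the aromatic nitrogen of compound 2 and compound 3, so no direct guide exists for the direction or size of this change. With compound 1 sitting at a limit and with most of the values shown sitting there, compound 4 is expected to remain weak, and a step of an at least 1.1-fold lower number from compound 1 to compound 4 (0.06 log units; that floor lies within the scatter) is estimated. Compound 4 is therefore expected to give about 130000 nM in this assay, within a range from 30000 nM to 500000 nM.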

Compound 4, half-maximal inhibitory concentration: > 150000 nM
Compound 4 gave a limit, no number; the forecaster's own chance of this, stated with the estimate: 65%; at least 1.1-fold (0.06 log units) between middle value and limit.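

Within the data shown here, compound 4 gives only a limit in this assay, as compound 1 does, so no step between compound 1 and compound 4 can be read: the limit of > 150000 nM in this assay, at which 3 of the 4 values shown sit. The compounds shown leave open whether 4-methoxyphenyl and 4-nitrophenyl differ at all in this read-out, and how either side chain would compare with the numbered value of compound 2.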